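Chlorination of compound 2 and expected cytotoxicity

The source may report more compounds than this note shows. Statements on the series, on what has been measured and on what is new or still open speak of the compounds shown alone.

Compound 1 `CC(c1nccs1)C(C#N)(C#N)CCC(F)=C(F)F` sets the scene only through a limit: in a functional assay on HepG2 cells (Homo sapiens) for cytotoxicity, read by MTT assay, with a stated time of 48 h (a lower number here means a stronger inhibitor, a higher number a weaker inhibitor), compound 1 gives > 120000 nM, which is a limit of the assay rather than a number. That value sits at the limit of > 120000 nM in this assay, at which 1 of the 2 values shown sits, so compound 1 contributes no measurable figure. Compound 2 `O=S(=O)(CCC(F)(Cl)C(F)(F)Cl)c1nc2ccccc2s1` is different: in this assay compound 2 gives 4500 nM, and this is the only number shown among the two values.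

Compound 3 `O=S(=O)(CCC(F)(Cl)C(F)(F)Cl)c1nc2ccc(Cl)cc2s1` has not yet been measured. It differs from compound 2 by chloro in place of hydrogen on an aromatic carbon. Among the measured compounds shown here, no step between measured compounds is available, so the size of the change cannot be read from any earlier pair. The author expects the step in this assay from compound 2 to compound 3 to be small, at most a modest move toward a stronger inhibitor, and quite possibly nothing beyond the usual scatter, as a 1.5-fold lower number from compound 2 to compound 3 (0.18 log units; within the scatter).

Compound 3 is therefore estimated at 3000 nM, expected to lie between 1000 nM and 10000 nM.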

Compound 3, half-maximal inhibitory concentration: 6100 nM
Estimate against measurement, compound 3: 2.0-fold (0.31 log units) below; measured number inside the range.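

In this assay, chloro in place of hydrogen on an aromatic carbon of the six-membered aromatic ring of carbon only gives a 1.4-fold higher number from compound 2 to compound 3 (0.13 log units; within the scatter), so compound 2 and compound 3 cannot be told apart in this read-out. This is the only step shown between compounds that differ in one place, and it gives the first direct reading at this position: this aromatic carbon accepts a chloro group with no difference beyond the usual scatter, and the rest of compound 2 is left as it stands. Nothing among the data shown bears on why the two compounds read alike, and this single pair gives no explanation for the result.

As far as these compounds go, what remains open is whether a different group on the same aromatic carbon, such as an amine, a carboxylic acid or a methoxy group, would carry the number beyond the scatter, or whether this position stays as undemanding as chloro suggests. Also open, from the compounds shown here alone, is whether chloro would read the same on another carbon of that ring, and whether a longer chain in place of the halogenated chain would alter the reading in this assay.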